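Swapping the halophenyl on a triazole across two related cores

The compounds below may be only part of what the source reports. "The series", "measured", "known", "first", "only" and "open" are said of these compounds alone.

Compound 1 `CC(C)=CCC/C(C)=C/CC/C(C)=C/CC[C@@H]1[C@@]2(C)CC/C(=N\OCc3cn(-c4ccc(Cl)cc4)nn3)C(C)(C)[C@@H]2CC[C@@]1(C)O` and compound 2 `CC(C)=CCC/C(C)=C/CC/C(C)=C/CC[C@@H]1[C@@]2(C)CC/C(=N\OCc3cn(-c4cccc(Br)c4)nn3)C(C)(C)[C@@H]2CC[C@@]1(C)O` share a core that carries a triazole joined through an oxime linker, and they differ only in one place: 3-bromophenyl in place of 4-chlorophenyl on an aromatic nitrogen. In a functional assay on DU-145 cells (Homo sapiens) for cytotoxicity, read by MTT assay, with a stated time of 48 h (a lower number here means a stronger inhibitor, a higher number a weaker inhibitor), compound 1 gives 16200 nM, and compound 2 gives 14600 nM. That change made a 1.1-fold lower number from compound 1 to compound 2 (0.05 log units; within the scatter).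

Compound 3 `CC(C)=CCC/C(C)=C/CC/C(C)=C/CC[C@@H]1[C@@]2(C)C/C(=C\c3ccc(OCc4cn(-c5ccc(Cl)cc5)nn4)cc3)C(=O)C(C)(C)[C@@H]2CC[C@@]1(C)O` belongs to a second core, in which the triazole hangs from a benzylidene attached to a ketone; how this core differs from the core of compound 1 is not broken down here. In this assay compound 3 gives 79400 nM, the highest of the three measured numbers.

Compound 4 `CC(C)=CCC/C(C)=C/CC/C(C)=C/CC[C@@H]1[C@@]2(C)C/C(=C\c3ccc(OCc4cn(-c5cccc(Br)c5)nn4)cc3)C(=O)C(C)(C)[C@@H]2CC[C@@]1(C)O` is to compound 3 what compound 2 is to compound 1: 3-bromophenyl in place of 4-chlorophenyl on an aromatic nitrogen. The two places read the same, so this is the same kind of change on a different core. Because the earlier step was a 1.1-fold lower number from compound 1 to compound 2 (0.05 log units; within the scatter), the step from compound 3 to compound 4 is expected to be small as well, estimated as a 1.1-fold lower number from compound 3 to compound 4 (0.04 log units; within the scatter). Compound 4 is therefore estimated at 72000 nM, with a likely range from 35000 nM to 150000 nM.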

Compound 4, half-maximal inhibitory concentration: 40500 nM
Compound 4: middle estimate off by 1.8-fold (0.25 log units), on the high side; measured number inside the range.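

On the core of compound 3, the swap gives a 2.0-fold lower number from compound 3 to compound 4 (0.29 log units; within the scatter) in this assay, so here too the change stays within what repeated measurements would be expected to show. Set beside the earlier step, the same swap gives a comparable result on both cores, and the two steps cannot be told apart: the same change on two cores in this assay, a 1.1-fold lower number (0.05 log units; within the scatter) from compound 1 to compound 2 and a 2.0-fold lower number (0.29 log units; within the scatter) from compound 3 to compound 4, 1.8-fold (0.25 log units) apart, within the scatter of two such steps. Among the compounds shown here, this supports carrying the change from one of these cores to the other as a small step, but it rests on only two pairs of compounds and does not show that the swap would stay small on any further core, and since the halogen and its place on the ring change together, it cannot say what either does alone.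

The compounds shown leave open how 3-chlorophenyl or 4-bromophenyl would compare, which would separate the halogen from its place on the ring. They also leave open whether an amine or a carboxylic acid on that phenyl ring would give a step beyond the scatter on either core.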